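The compounds below may be only part of what the source reports. "The series", "measured", "known", "first", "only" and "open" are said of these compounds alone.

Compound 3, `O=C(COc1cccc2ccccc12)N/N=C/c1ccc(F)cc1`, is assessed in an ADME assay on HEL cells (Homo sapiens) for cytotoxicity (on this read-out lower numbers stand for higher toxicity in this test and higher numbers for lower toxicity in this test), where compound 3 gives 100 ug/mL. Two measured neighbours frame it. Compound 1, `O=C(COc1cccc2ccccc12)N/N=C/c1ccc([N+](=O)[O-])cc1`, gives 20 ug/mL in this assay, and the step of a 5.0-fold higher number from compound 1 to compound 3 (0.70 log units; beyond the scatter) is modest but beyond the scatter. Compound 2, `O=C(COc1cccc2ccccc12)N/N=C/c1cccc(Br)c1`, gives 100 ug/mL in this assay, and the step of no change at the digits printed from compound 2 to compound 3 (within the scatter) shows that compound 2 and compound 3 stand level at the digits recorded, together the highest of the three numbers, with compound 1 furthest from compound 3.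

Compound 4, `O=C(COc1cccc2ccccc12)N/N=C/c1ccc(Br)cc1`, differs from compound 3 in one place: bromo in place of fluoro on an aromatic carbon. Among the compounds with values here, the step that bears most directly on this is the one from compound 2 to compound 3, in which a bromo-bearing ring replaced by a fluoro-bearing ring left the number unchanged. The step from compound 1 to compound 3 involved a nitro group and is less informative here. On that basis no step beyond the scatter is expected from compound 3 to compound 4, so no change at the digits printed from compound 3 to compound 4 (within the scatter) is the estimated change. Compound 4 is therefore expected to give about 100 ug/mL in this assay, with a range from 50 ug/mL to 200 ug/mL.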

Compound 4, minimum cytotoxic concentration in the HEL assay: > 100 ug/mL
Compound 4: only a limit was reported (the forecaster's own chance of this, stated with the estimate: 10%); the middle value lies on the limit itself.
By their numbers in the HEL assay, from the lowest: compound 1; then compounds 2 and 3 (each within the scatter of the next).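

In the HEL assay compound 4 gives > 100 ug/mL, which is a limit and not a number. In the HEL assay the steps of a number no lower from compound 3 to compound 4 (the limit leaves the size open) and a number no lower from compound 2 to compound 4 (the limit leaves the size open) cannot be read for size. In the HEL assay one new step can be read, an at least 5.0-fold higher number from compound 1 to compound 4 (0.69 log units; beyond the scatter), so at this place, para to a large group, bromo, like fluoro, gives a higher number than nitro. In a physicochemical assay for lipophilicity, measured as octanol-water partition (on this read-out lower numbers stand for lower lipophilicity and higher numbers for higher lipophilicity), compound 3 gives 4.16 and compound 4 gives 4.81. In the physicochemical assay this is a number 0.65 log units higher from compound 3 to compound 4 (beyond the scatter).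

As far as these compounds go, how far compound 4 truly stands from compound 2 and compound 3 stays open. So does whether an amine or a carboxylic acid at this place would fall with nitro or stay with fluoro and bromo.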